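The source may hold more compounds than are shown below. What is called first, only, known or untested is meant among the compounds shown, and "the series" means these compounds.

Compound 1 `Cc1nc(N2CCN(C(=O)[C@@H]3CN[C@H](C(=O)N4CCCC4)C3)CC2)no1` gives 960 nM in an assay on a cell-free system (plasma) for inhibition of Dipeptidyl peptidase 4 (Rattus norvegicus), read by fluorescence; on this read-out higher numbers stand for weaker inhibition and lower numbers for stronger inhibition.
Compound 2 `O=C([C@@H]1CN[C@H](C(=O)N2CCCC2)C1)N1CCN(c2nc(-c3ccccc3)ns2)CC1` gives 150 nM in this assay.

Compound 2 carries the lowest of the two numbers; compound 1 sits well above it, beyond the usual scatter. Compound 3 `CCCc1nsc(N2CCN(C(=O)[C@@H]3CN[C@H](C(=O)N4CCCC4)C3)CC2)n1` differs from compound 2 in one place: propyl in place of phenyl on an aromatic carbon. Going by the values given here, no measured pair shows this same change, so its size cannot be read from the data. A modest shift toward weaker inhibition is expected, with the step from compound 2 to compound 3 estimated at a 2.0-fold higher number from compound 2 to compound 3 (0.30 log units; within the scatter). Compound 3 is therefore expected to give about 300 nM, likely within 100 nM to 900 nM.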

Compound 3, half-maximal inhibitory concentration: 110 nM
Estimate against measurement, compound 3: 2.7-fold (0.44 log units) above, and the stated range covers the measured number.
By their numbers in this assay, from the lowest: compounds 3 and 2 (each within the scatter of the next); then compound 1.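

Replacing phenyl with propyl on this aromatic carbon gives a 1.4-fold lower number from compound 2 to compound 3 (0.13 log units; within the scatter) in this assay, so a ring at this position is not required for inhibition at this level. Exchanging the whole ring system with its substituent on the amine nitrogen matters more, with an 8.7-fold lower number from compound 1 to compound 3 (0.94 log units; beyond the scatter). Nothing measured here gives a reason for either step.

Going by these compounds, whether a longer chain such as butyl or an amine on this carbon would keep the number stays open. Also open, on these data alone, is how the step from compound 1 divides between the ring and its substituent.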